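This account rests on a few compounds, and the source may have more. Where it says the series, first, only, none or still open, it means among the compounds named here.

Among the measured compounds shown here, in a functional assay on the whole organism with Mus musculus as the target, in the writhing test (on this read-out lower numbers stand for an effect already at smaller amounts and higher numbers for an effect only at larger amounts of compound), three compounds have values so far. Compound 1 `CCCCSc1nsnc1C1CN2CCC1CC2` gives 0.19 mg/kg, compound 2 `FC(F)(F)CCCCSc1nsnc1[C@@H]1CN2CCC[C@@H]1C2` gives 0.07 mg/kg, and compound 3 `CC(C)CCCSc1nsnc1C1CN2CCCC1C2` gives 0.95 mg/kg. Compound 2 therefore stands lowest of the three, and its gaps to both of the others lie beyond the usual scatter.

The next compound, compound 4 `FC(F)(F)CCSc1nsnc1[C@@H]1CN2CCC[C@@H]1C2`, differs from compound 2 in one place: trifluoromethyl in place of 3,3,3-trifluoropropyl on a saturated chain carbon, two bonds along the chain from a sulfur. Trifluoromethyl stands in place of 3,3,3-trifluoropropyl on a saturated chain carbon, two bonds along the chain from a sulfur. For the measured compounds named here, no measured pair of compounds shows this kind of change on its own, so the expectation rests on little. Compound 2 stands lowest at 0.07 mg/kg, so the change is expected to move the number upward rather than downward, and a moderate rise beyond the scatter seems most likely. The expected size of this rise is a 4.3-fold higher number from compound 2 to compound 4 (0.63 log units; beyond the scatter). For compound 4 the estimated value is 0.3 mg/kg, with an expected range from 0.08 mg/kg to 1.1 mg/kg.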

Compound 4, dose for half-maximal effect: 0.1 mg/kg
The estimate for compound 4 lay 3.0-fold (0.48 log units) above the measured number, and the stated range covers the measured number.
By their numbers in this assay, from the lowest: compounds 2, 4 and 1 (each within the scatter of the next, the first and the last beyond it); then compound 3.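

In this assay, among the compounds shown here, the exchange at this place gives a 1.4-fold higher number from compound 2 to compound 4 (0.15 log units; within the scatter), the first step between compounds that differ in one place only. Read as 4,4,4-trifluorobutyl to 2,2,2-trifluoroethyl, the change shows that the two chains cannot be told apart on this read-out, so this position accepts the shorter fluorinated chain without a change beyond the scatter. Nothing shown here bears on why the two chains read alike.

As far as these compounds go, it stays open whether this holds on the same core for a longer fluorinated chain, a chain without fluorine, or a chain ending in an amine or a carboxylic acid. Compound 1 and compound 3 differ from these two in more than one place, so they cannot settle that question.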